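From isobutyl to 2-ethoxyethyl on a shared core

This account rests on a few compounds, and the source may have more. Where it says the series, first, only, none or still open, it means among the compounds named here.

Measured so far in a functional assay (Nicotiana tabacum) (on this read-out lower numbers stand for stronger inhibition and higher numbers for weaker inhibition), are three compounds:
compound 1 `CNc1nc(SC)nc2ncccc12` gives 2920 nM
compound 2 `CCCCCCCNc1nc(SC)nc2ncccc12` gives 4070 nM
compound 3 `CSc1nc(NCC(C)C)c2cccnc2n1` gives 540 nM

Compound 3 has the lowest number of the three, and its gaps to the other two lie beyond the scatter. The measured steps show a 5.4-fold lower number from compound 1 to compound 3 (0.73 log units; beyond the scatter) and a 7.5-fold lower number from compound 2 to compound 3 (0.88 log units; beyond the scatter), both modest. By contrast, a 1.4-fold higher number from compound 1 to compound 2 (0.14 log units; within the scatter) stays within the scatter.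

The next compound, compound 4 `CCOCCNc1nc(SC)nc2ncccc12`, keeps the shared core and carries ethoxymethyl in place of isopropyl on a saturated chain carbon bound to a nitrogen on an aromatic ring. Cut one bond further out, this is isobutyl to 2-ethoxyethyl.

Among the compounds with values here, no measured step brings in an oxygen, so the evidence is indirect. Among these compounds, only compound 3 carries isopropyl, and compound 4 gives it up. The two steps into compound 3 therefore suggest a modest move back towards a higher number, probably somewhat smaller than those steps. The expected change is a 2.8-fold higher number from compound 3 to compound 4 (0.44 log units; beyond the scatter) in this assay, though a result within the scatter remains possible. For compound 4 the estimated value is 1500 nM (expected range 500 nM to 4500 nM).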

Compound 4, half-maximal inhibitory concentration: 7590 nM
For compound 4 the middle estimate is 5.1-fold (0.70 log units) below the measured one; the measured number lies above the stated range.
By their numbers in this assay, from the lowest: compound 3; then compounds 1, 2 and 4 (each within the scatter of the next, the first and the last beyond it).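

In this assay, going from isobutyl to 2-ethoxyethyl is a sharp reversal rather than a slight one: a 14-fold higher number from compound 3 to compound 4 (1.15 log units; beyond the scatter), the largest step among these compounds. The 2-ethoxyethyl chain does not even hold the level of the much smaller group on compound 1, a 2.6-fold higher number from compound 1 to compound 4 (0.41 log units; beyond the scatter), and it cannot be told apart from the long chain of compound 2, a 1.9-fold higher number from compound 2 to compound 4 (0.27 log units; within the scatter). At this position, then, the low number belongs to the isobutyl of compound 3 alone, and chain size by itself does not order these four compounds, as the smallest and the largest chains both give higher numbers than isobutyl.

Nothing available here accounts for why the 2-ethoxyethyl chain lands where it does. Open too, from the compounds shown here alone, is whether the rise in the number goes with the added oxygen or with the branched end that is given up, which a straight butyl chain, a 2-methoxyethyl group or a branched chain with an ether oxygen could help to separate.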